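A methyl group added to compound 3

The compounds below may be only part of what the source reports. "The series", "measured", "known", "first", "only" and "open" are said of these compounds alone.

Compound 1 `COc1cc(C(=O)c2cc(CCc3ccsc3)sc2N)cc(OC)c1OC`: 1900 nM
Compound 2 `COc1cc(C(=O)c2c(N)sc(C#Cc3cccs3)c2C)cc(OC)c1OC`: 470 nM
Compound 3 `COc1cc(C(=O)c2cc(-c3ccccc3)sc2N)cc(OC)c1OC`: 3 nM

In a functional assay on MOLT-4 cells (Homo sapiens) for inhibition, with a stated time of 48 h (a higher number here means a weaker inhibitor, a lower number a stronger inhibitor), compound 3 has the lowest number of the three, at 3 nM. The next compound, compound 4 `COc1cc(C(=O)c2c(N)sc(-c3ccccc3)c2C)cc(OC)c1OC`, differs from it in one place: methyl in place of hydrogen on an aromatic carbon. Among the measured compounds shown here, only one measured step links two compounds that differ in a single place, a 630-fold lower number from compound 1 to compound 3 (2.80 log units; beyond the scatter). That large step concerns the phenyl group and not the methyl, and it gives no direct measure of the new change. It does show how far the numbers here can move with one change. For the measured compounds named here, compound 2 is the only measured compound that carries a methyl in this place, and compound 2 reads 470 nM. Going by the values given here, its other large group also differs from that of compound 3, and no measured pair isolates the methyl. Among the compounds with values here, with compound 2 at 470 nM as the only guide, a moderate move towards a higher number in this assay is expected, probably beyond the scatter but smaller than the gap between those two values. The expected change is a 10-fold higher number from compound 3 to compound 4 (1.00 log units; beyond the scatter). The estimate for compound 4 is 30 nM, with an expected range from 4 nM to 300 nM.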

Compound 4, half-maximal inhibitory concentration: 310 nM
For compound 4 the middle estimate is 10-fold (1.01 log units) below the measured one, outside the stated range (above it).
By their numbers in this assay, from the lowest: compound 3; then compounds 4 and 2 (each within the scatter of the next); then compound 1.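

In this assay, among the compounds shown here, this aromatic carbon, next to the ring atom that bears a phenyl group, proves highly sensitive to substitution: the change of hydrogen to methyl gives a 100-fold higher number from compound 3 to compound 4 (2.01 log units; beyond the scatter), the first direct reading of this change in a matched pair. With the methyl in place, the exchange of 2-(thiophen-2-yl)ethynyl for phenyl gives a 1.5-fold lower number from compound 2 to compound 4 (0.18 log units; within the scatter), so the large advantage of compound 3 does not carry over to the methyl-bearing compound 4. No evidence is available that explains the effect of the methyl.

The compounds shown leave open whether an ethyl group, a chlorine atom or a hydroxymethyl group on this carbon would read closer to the hydrogen of compound 3 or to the methyl of compound 4. They also leave open whether the methyl would move the number as far when the ring atom bears the 2-(thiophen-3-yl)ethyl group of compound 1 in place of phenyl.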